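Cytotoxicity Limits Across Ether and Thioether Analogues of One Core

A few compounds are considered here, and "the series" means these few. Any claim that something is new, unique, unknown or untested is made for them only; others in the source may bear on it.

The measured compounds are these. Compound 1 `CCCCCCCCOc1nc(N)nc2c1ncn2/C=C1/CC1(CO)CO`: in an ADME assay on HFF cells (Homo sapiens) for cytotoxicity, with a stated time of 8 days (a higher number here means that more compound is tolerated, a lower number that less compound is tolerated), compound 1 gives > 300000 nM, which is a limit of the assay. Compound 2 `Nc1nc(OCC(F)(F)F)c2ncn(/C=C3/CC3(CO)CO)c2n1`: in this assay compound 2 gives > 300000 nM, again a limit. Compound 3 `CCCCCCOc1nc(N)nc2c1ncn2/C=C1/CC1(CO)CO`: in this assay compound 3 gives > 200000 nM, also a limit.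

Compound 2 therefore stands at the limit of > 300000 nM in this assay, at which 2 of the 3 values shown sit, and no number places it above or below the others. For the measured compounds named here, the change from compound 1 to compound 2 gives a step that the two limits leave unreadable from compound 1 to compound 2, the change from compound 1 to compound 3 gives a step that the two limits leave unreadable from compound 1 to compound 3, and the change from compound 2 to compound 3 gives a step that the two limits leave unreadable from compound 2 to compound 3; with every value a limit, none of these steps can be sized, and the limit of > 200000 nM in this assay, at which 1 of the 3 values shown sits, marks the one value that sits lower.

Compound 4 `Nc1nc(SCc2ccccc2)c2ncn(/C=C3/CC3(CO)CO)c2n1` differs from compound 2 by benzylsulfanyl in place of 2,2,2-trifluoroethoxy on an aromatic carbon. Going by the values given here, no measured step bears on this change, since the three values give no readable step of any size in this assay. The estimate for compound 4 is accordingly 100000 nM, between 20000 nM and 300000 nM, which would mean an expected step of an at least 3.0-fold lower number from compound 2 to compound 4 (0.47 log units; beyond the scatter) from compound 2 to compound 4.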

Compound 4, half-maximal cytotoxic concentration: > 300000 nM
Compound 4: a limit, no number; the forecaster's own chance of this, stated with the estimate: 45%; middle value at least 3.0-fold (0.47 log units) from the limit.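

In this assay, for the compounds shown here, compound 4 gives > 300000 nM, which is a limit and not a number, and no step from compound 1, compound 2 or compound 3 to compound 4 can be read. Compound 4 joins the upper limit: the limit of > 300000 nM in this assay, at which 3 of the 4 values shown sit.

The compounds shown leave open whether any of these groups on the aromatic carbon, benzylsulfanyl included, alters the tolerated concentration at all.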